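From tert-butoxy to sec-butoxy on a shared core

The source may hold more compounds than are shown below. What is called first, only, known or untested is meant among the compounds shown, and "the series" means these compounds.

Of the compounds shown here, two have been measured so far in a functional assay on Hs68 cells (Homo sapiens) for cytotoxicity; a lower number here means that less compound is tolerated, a higher number that more compound is tolerated. Compound 1 (`CC(C)Oc1ccccc1CNC(=O)c1ccc2cncc(Cl)c2n1`) gives 6 ug/mL, and compound 2 (`CC(C)(C)Oc1ccccc1CNC(=O)c1ccc2cnccc2n1`) gives 4.4 ug/mL. Among the measured compounds shown here, these two values lie within the scatter of each other, so the numbers do not separate compound 2 from the only other measurement. Compound 3 (`CC[C@H](C)Oc1ccccc1CNC(=O)c1ccc2cnccc2n1`) has not yet been measured. It has the same atoms as compound 2, joined differently, with sec-butyl in place of tert-butyl on an oxygen on an aromatic ring. For the measured compounds named here, no measured pair shows a change of this kind, so the data give no direct guide to its size or direction. No shift beyond the scatter is therefore expected in this assay. The estimate is a 1.1-fold higher number from compound 2 to compound 3 (0.06 log units; within the scatter), which stays within the scatter. Compound 3 is expected at 5 ug/mL, with an estimated range of 2.5 ug/mL to 10 ug/mL.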

Compound 3, half-maximal cytotoxic concentration: 3.1 ug/mL
Compound 3: middle estimate off by 1.6-fold (0.21 log units), on the high side; measured number inside the range.
By their numbers in this assay, from the lowest: compounds 3, 2 and 1 (each within the scatter of the next).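

In this assay, placing sec-butyl in place of tert-butyl on an oxygen on an aromatic ring gives a 1.4-fold lower number from compound 2 to compound 3 (0.15 log units; within the scatter), which is within the scatter. Among the compounds shown here, this is the first step that reads this position directly: two butyl groups with the same atoms, joined differently, are not separated by this measurement, and the defined stereocentre that enters with sec-butyl brings no shift beyond the scatter. Nothing available on these compounds offers an explanation for this result. On these data alone, it remains open whether the opposite configuration of the sec-butyl group would also stay within the scatter. Also open, as far as these compounds go, is whether a longer chain such as n-hexyl, a cyclohexyl ring or an amine-bearing chain on the same oxygen would move the number beyond it.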